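Working notes: compound 4 against compound 3 in this series

The source may hold more compounds than are shown below. What is called first, only, known or untested is meant among the compounds shown, and "the series" means these compounds.

Measured so far:
compound 1 `Clc1cccc2c1CC2CCN1CCN(c2cccc3c2OCCO3)CC1` — 1.25 mg/kg
compound 2 `c1ccc2c(c1)CC2CCCN1CCN(c2cccc3c2OCCO3)CC1` — 0.16 mg/kg
compound 3 `C1=C(CCN2CCN(c3cccc4c3OCCO4)CC2)c2ccccc2C1` — 0.63 mg/kg

All three numbers come from a functional assay on the whole organism for antagonist activity, with Rattus norvegicus as the target; a higher number here means that more compound is needed for the effect, a lower number that less compound is needed. Compound 3 stands second highest of the three: against compound 1 the gap is within the scatter, whereas the step of a 3.9-fold higher number from compound 2 to compound 3 (0.60 log units; beyond the scatter) is beyond it.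

Compound 4 `c1ccc2c(c1)CC(CCN1CCN(c3cccc4c3OCCO4)CC1)C2` differs from compound 3 by a group of 9 heavy atoms (9 carbon; one five-membered non-aromatic ring of carbon only, one six-membered aromatic ring of carbon only) in place of a group of 9 heavy atoms (9 carbon; one five-membered non-aromatic ring of carbon only, one six-membered aromatic ring of carbon only), on a saturated chain carbon, two bonds along the chain from an amine nitrogen in a ring.

Among the compounds with values here, none of the measured steps covers this change. The steps of a 7.8-fold lower number from compound 1 to compound 2 (0.89 log units; beyond the scatter) and a 2.0-fold lower number from compound 1 to compound 3 (0.30 log units; within the scatter) alter the size of the fused ring or remove a chlorine, and neither speaks to the double bond. Within the data shown here, with no comparable step at hand, no movement beyond the scatter is expected, in either direction.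

Compound 4 is therefore expected near 0.6 mg/kg, with a range from 0.2 mg/kg to 2 mg/kg. This estimate means a step of a 1.1-fold lower number from compound 3 to compound 4 (0.02 log units; within the scatter), expected to stay within the scatter.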

Compound 4, minimum effective dose: 0.16 mg/kg
Estimate against measurement, compound 4: 3.8-fold (0.57 log units) above; measured number below the stated range.
By their numbers in this assay, from the lowest: compounds 2 and 4 (each within the scatter of the next); then compounds 3 and 1 (each within the scatter of the next).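

In this assay, putting 2,3-dihydro-1H-inden-2-yl on this saturated chain carbon, in place of the group with a double bond outside aromatic rings, gives a 3.9-fold lower number from compound 3 to compound 4 (0.60 log units; beyond the scatter), so a change that keeps the heavy-atom count and ring types still moves the number beyond the scatter. The same group gives no change at the digits printed from compound 2 to compound 4 (within the scatter) and a 7.8-fold lower number from compound 1 to compound 4 (0.89 log units; beyond the scatter), so a group with a five-membered non-aromatic ring can match the four-membered group of compound 2. Nothing available explains the step from the unsaturated to the saturated group. Open, going by these compounds, is whether a longer chain or an amine on 2,3-dihydro-1H-inden-2-yl would hold this level.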